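The compounds below may be only part of what the source reports. "The series", "measured", "known", "first", "only" and "open" are said of these compounds alone.

Measured in a functional assay on BV-2 cells (Mus musculus) for inhibition, read by Griess assay, with stated times of 3 h and 24 h; on this read-out lower numbers stand for stronger inhibition and higher numbers for weaker inhibition:

- compound 1 `O=S(=O)(/C=C/c1ccc(O)c(O)c1)Cc1ccccc1`: 11600 nM
- compound 2 `O=S(=O)(/C=C/c1ccc(O)c(O)c1)Cc1ccc(Cl)cc1`: 11700 nM
- compound 3 `[O-][S+](/C=C/c1ccc(O)c(O)c1)Cc1ccccc1`: 50300 nM

Compound 1 and compound 2 share one core and differ by a single change, (chloro in place of hydrogen on an aromatic carbon). That change produced a 1.0-fold higher number from compound 1 to compound 2 (0.00 log units; within the scatter), so on this core the chloro neither helped nor hurt in this assay.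

Compound 3 carries a different core; how the core of compound 3 differs from the core of compound 1 is not broken down here. In this assay compound 3 stands at the highest number of the three, and its distance from both compound 1 and compound 2 is beyond the scatter, so the core of compound 3 reads as the weaker of the two cores.

Compound 4 `[O-][S+](/C=C/c1ccc(O)c(O)c1)Cc1ccc(Cl)cc1` is compound 3 with the change (chloro in place of hydrogen on an aromatic carbon). Among the compounds with values here, it is the same change as the one from compound 1 to compound 2, made at the same place on the same kind of ring, only now on the core of compound 3. Within the data shown here, only one measured instance of this change exists, and it lies within the scatter. Among the measured compounds shown here, the expectation for compound 4 in this assay is therefore a step of a 1.0-fold lower number from compound 3 to compound 4 (0.00 log units; within the scatter), resting on the single measured step of a 1.0-fold higher number from compound 1 to compound 2 (0.00 log units; within the scatter), with the caveat that a change seen once on one core need not carry over to another core. Compound 4 is estimated at 50000 nM, expected to fall between 22000 nM and 110000 nM.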

Compound 4, half-maximal inhibitory concentration: 14000 nM
Estimate against measurement, compound 4: 3.6-fold (0.55 log units) above; the measured number lies below the stated range.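

On the core of compound 3, chloro in place of hydrogen on an aromatic carbon gives, in this assay, a 3.6-fold lower number from compound 3 to compound 4 (0.56 log units; beyond the scatter), a modest gain that the core of compound 1 did not show. The size of this step therefore does not transfer from one core to the other, and the effect of the change in this series depends on the core it is made on: the same change on two cores in this assay, a 1.0-fold higher number (0.00 log units; within the scatter) from compound 1 to compound 2 and a 3.6-fold lower number (0.56 log units; beyond the scatter) from compound 3 to compound 4, 3.6-fold (0.56 log units) apart, beyond the scatter of two such steps This rests on one pair per core with a single group at a single place, so it shows that the two cores can differ but gives no rule for any further core and does not explain why they differ.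

The compounds shown leave open whether the gain on the core of compound 3 belongs to chloro alone or would also appear with fluoro, bromo, methoxy or an amine at the same place on the ring. They also leave open whether a carboxylic acid there would separate the two cores in the same way, or whether the two cores would then read alike.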